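A few compounds are considered here, and "the series" means these few. Any claim that something is new, unique, unknown or untested is made for them only; others in the source may bear on it.

Compound 1 `N#CC1=C(N)Oc2c(N)cc3nc4ccccc4nc3c2C12C(=O)N(Cc1cnnn1-c1ccccc1Cl)c1ccccc12` and compound 2 `N#CC1=C(N)Oc2c(N)cc3nc4ccccc4nc3c2C12C(=O)N(Cc1cnnn1-c1ccc([N+](=O)[O-])cc1)c1ccccc12` share a core and differ only in the group on the aromatic nitrogen. In a functional assay on MCF7 cells (Homo sapiens) for antiproliferative activity, read by MTT assay, with a stated time of 48 h (a higher number here means a weaker inhibitor, a lower number a stronger inhibitor), compound 1 gives 34400 nM. For compound 2 this assay reports only a limit, > 50000 nM, so compound 2 stands at the edge of what the assay can resolve, as the limit of > 50000 nM in this assay, at which 1 of the 2 values shown sits, records. Going by the values given here, the single measured step, an at least 1.4-fold higher number from compound 1 to compound 2 (0.16 log units; that floor lies within the scatter), is therefore known only as a floor.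

Compound 3 `CCc1cccc(C)c1-n1nncc1CN1C(=O)C2(C(C#N)=C(N)Oc3c(N)cc4nc5ccccc5nc4c32)c2ccccc21` is the next variant: 2-ethyl-6-methylphenyl in place of 4-nitrophenyl on an aromatic nitrogen. Among the compounds with values here, no measured step covers an exchange of this kind; the only comparison available on that aromatic nitrogen is the one from compound 1 to compound 2, which was modest and bounded. On that basis the step from compound 2 to compound 3 in this assay is expected to be small, with no clear direction, and compound 3 is expected to remain weak, with the estimated shift an at least 1.1-fold lower number from compound 2 to compound 3 (0.04 log units; that floor lies within the scatter). For compound 3 the expected value in this assay is 45000 nM, within a range from 15000 nM to 150000 nM, and a limit rather than a number is a real possibility.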

Compound 3, half-maximal inhibitory concentration: > 50000 nM
Compound 3: no number, only a limit; the forecaster's own chance of this, stated with the estimate: 45%; middle value at least 1.1-fold (0.04 log units) away from the limit.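

Compound 3 now stands with compound 2 at a limit rather than a number: the limit of > 50000 nM in this assay, at which 2 of the 3 values shown sit. Replacing the 2-chlorophenyl group of compound 1 with 2-ethyl-6-methylphenyl gives an at least 1.4-fold higher number from compound 1 to compound 3 (0.16 log units; that floor lies within the scatter), so this change, like the one to 4-nitrophenyl, is known only as a floor that lies within the scatter. The step from compound 2 to compound 3 cannot be read, so 4-nitrophenyl and 2-ethyl-6-methylphenyl cannot be put in any order, and a group with no hydrogen-bond acceptors on this aromatic nitrogen gives no number where the nitro-bearing group gave none either.

Going by these compounds, it remains open whether a phenyl ring carrying an amine or a carboxylic acid, or a plain phenyl ring with no substituent, would give a number on this aromatic nitrogen rather than a limit. On these data alone, it is also open how far the true values of compound 2 and compound 3 lie from compound 1, or from each other.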